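The compounds below may be only part of what the source reports. "The series", "measured", "known", "first", "only" and "open" are said of these compounds alone.

Compound 1 `COc1cc(-n2cnc3ccc(-c4ccccc4Cl)cc32)cc(OC)c1OC`: in a functional assay on SGC-7901 cells (Homo sapiens) for antiproliferative activity, read by MTT assay, with a stated time of 72 h (a higher number here means a weaker inhibitor, a lower number a stronger inhibitor), compound 1 gives > 10000 nM, which is a limit of the assay and not a number.
Compound 2 `COc1cc(-n2cnc3ccc(-c4ccc(C(F)(F)F)cc4)cc32)cc(OC)c1OC`: in this assay compound 2 gives 890 nM.
Compound 3 `COc1cc(-n2cnc3ccc(-c4ccc(C)cc4)cc32)cc(OC)c1OC`: in this assay compound 3 gives 200 nM.

Going by the values given here, compound 2 has the highest of the two numbers that were actually measured; the only other number, that of compound 3, is lower by a 4.5-fold lower number from compound 2 to compound 3 (0.65 log units; beyond the scatter). The remaining value, that of compound 1, is a limit (the limit of > 10000 nM in this assay, at which 1 of the 3 values shown sits).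

Compound 4 `COc1ccc(-c2ccc3ncn(-c4cc(OC)c(OC)c(OC)c4)c3c2)cc1` has not yet been measured. It differs from compound 2 in one place: methoxy in place of trifluoromethyl on an aromatic carbon.

Among the compounds with values here, two measured steps bear on this. The step of an at least 50-fold lower number from compound 1 to compound 3 (1.69 log units; beyond the scatter) and the step of an at least 11-fold lower number from compound 1 to compound 2 (1.05 log units; beyond the scatter) both start from a limit and say little about the group on the outer ring beyond the fact that a 4-substituted phenyl works. The closest guide is a 4.5-fold lower number from compound 2 to compound 3 (0.65 log units; beyond the scatter), where methyl in place of trifluoromethyl gave a modest gain. Methoxy is also a small group on the same aromatic carbon, so a gain of similar size is expected, with the direction somewhat uncertain. The estimated step is a 3.6-fold lower number from compound 2 to compound 4 (0.55 log units; beyond the scatter). Compound 4 is therefore expected to give about 250 nM in this assay, within a range from 80 nM to 900 nM.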

Compound 4, half-maximal inhibitory concentration: 82 nM
Compound 4: the middle estimate sits 3.0-fold (0.48 log units) above what was measured, and the stated range covers the measured number.
By their numbers in this assay, from the lowest: compound 4; then compound 3; then compound 2. At a limit, above all of these: compound 1.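

Methoxy on this aromatic carbon lowers the number from trifluoromethyl further than methyl did (an 11-fold lower number from compound 2 to compound 4 (1.04 log units; beyond the scatter)), and it also improves on methyl itself (a 2.4-fold lower number from compound 3 to compound 4 (0.39 log units; beyond the scatter)). The group para to a large group therefore still matters among small substituents, and compound 4 is the strongest inhibitor of the series in this assay. Compound 1 stands at a limit of the assay and not a number, so the step that swaps the whole outer group (an at least 120-fold lower number from compound 1 to compound 4 (2.08 log units; beyond the scatter)) gives only a minimum size.

Nothing shown explains why methoxy gives the lowest number. Going by these compounds, whether ethoxy, hydroxyl or an amine on the same carbon would go lower or higher remains open, as does the effect of methoxy on other carbons of that ring.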